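Swapping Fluoro for Chloro on a Calpain-1 Inhibitor

This account rests on a few compounds, and the source may have more. Where it says the series, first, only, none or still open, it means among the compounds named here.

Among the measured compounds shown here, compound 1 `O=C(O)/C(S)=C/c1c[nH]c2ccc(F)cc12` is, in an assay on isolated protein for inhibition of Calpain-1 catalytic subunit (Sus scrofa) (a higher number here means a weaker inhibitor, a lower number a stronger inhibitor), the stronger of the two compounds measured so far: compound 1 gives 930 nM. Compound 2 `O=C(O)/C(S)=C/c1cccc(F)c1` lacks the fused core of compound 1; in this assay compound 2 gives 31500 nM, a far higher number that lies well beyond the usual scatter. Compound 3 `O=C(O)/C(S)=C/c1c[nH]c2ccc(Cl)cc12` has not yet been measured. It differs from compound 1 in one place only: chloro in place of fluoro on an aromatic carbon. For the measured compounds named here, no measured pair shows what such a swap does here, so the expectation rests on how little the structure changes. Exchanging one halogen for another at the same spot is expected to move the half-maximal inhibitory concentration only slightly, if at all, so the step of a 1.2-fold lower number from compound 1 to compound 3 (0.09 log units; within the scatter) is expected to stay within the scatter. Compound 3 is therefore estimated at 750 nM, with a likely range from 250 nM to 2500 nM.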

Compound 3, half-maximal inhibitory concentration: 50 nM
For compound 3 the middle estimate is 15-fold (1.18 log units) above the measured one; the measured number lies below the stated range.
By their numbers in this assay, from the lowest: compound 3; then compound 1; then compound 2.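

In this assay, this aromatic carbon on the shared core proves highly sensitive to which halogen it carries: chloro in place of fluoro gives a 19-fold lower number from compound 1 to compound 3 (1.27 log units; beyond the scatter). The earlier compounds shown here could not show this, since compound 1 and compound 2 differ by the whole fused core, whereas here a single heavy atom is exchanged, with no change in hydrogen-bond donors, acceptors or net charge, and the number still falls sharply. Nothing available explains why the chloro compound gives the lower number.

The compounds shown leave open whether bromo, methyl or methoxy on this same carbon would lower the number further or raise it again. They also leave open whether chloro in place of fluoro would bring a similar step on the simpler ring of compound 2.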